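The source may report more compounds than this note shows. Statements on the series, on what has been measured and on what is new or still open speak of the compounds shown alone.

Working notes on the series.

Compound 1 `COc1ccc(-c2cc(/C=C/C(=O)c3ccc(N)cc3)[nH]n2)cc1` and compound 3 `COc1ccc(-c2cc(/C=C/C(=O)c3ccc(N)cc3)[nH]n2)cc1OC` share one core; compound 2 `COc1ccc(C(=O)/C=C/c2cc(-c3cc(OC)c(OC)c(OC)c3)n[nH]2)cc1OC` and the unmeasured compound 4 `COc1cc(C(=O)/C=C/c2cc(-c3cc(OC)c(OC)c(OC)c3)n[nH]2)cc(OC)c1OC` share another. The difference between the two cores is not broken down here.

In a functional assay on NCI-H226 cells (Homo sapiens) for cytotoxicity, read by sulforhodamine B assay, with a stated time of 48 h, tested at 10 uM (a higher number here means a weaker effect of the compound at the concentration tested, a lower number a stronger effect), compound 1 gives -29%. Compound 3 gives -13% in this assay. The step of a number 16 percentage points higher from compound 1 to compound 3 (beyond the scatter) corresponds to the change (methoxy in place of hydrogen on an aromatic carbon). In this assay compound 2 gives -81%, the lowest of the three numbers, and its gaps to compound 1 and to compound 3 are both beyond the scatter.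

Compound 4 arises from compound 2 by methoxy in place of hydrogen on an aromatic carbon. This is the same kind of change as that from compound 1 to compound 3, not the same change: in compound 4 the entering methoxy is additionally meta to a methoxy group, which is not the case in compound 3. Among the measured compounds shown here, the measured step of this kind moved the number upward by a modest amount, so a step of comparable size is expected from compound 2 to compound 4, namely a number 16 percentage points higher from compound 2 to compound 4 (beyond the scatter), resting on the one measured instance a number 16 percentage points higher from compound 1 to compound 3 (beyond the scatter) and on the starting value of compound 2, -81%. For compound 4 the estimated value in this assay is -65%, expected to fall between -88% and -40%. For the measured compounds named here, only one measured instance of this kind of change is available, so the expectation is correspondingly uncertain.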

Compound 4, a percentage reported as activity, at one concentration (the size of the read-out at that concentration, not a potency): -92%
Estimate against measurement, compound 4: 27 percentage points above; measured number outside the range, below it.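

The new step in this assay, a number 11 percentage points lower from compound 2 to compound 4 (beyond the scatter), comes from the same kind of change as the earlier one, methoxy in place of hydrogen on an aromatic carbon, yet the two steps differ in direction as well as in number: the same change on two cores in this assay, a number 16 percentage points higher (beyond the scatter) from compound 1 to compound 3 and a number 11 percentage points lower (beyond the scatter) from compound 2 to compound 4, 27 percentage points apart, beyond the scatter of two such steps. In this series, then, the change does not carry from one core to the other as a fixed increment, and the step measured on the core of compound 1 cannot be applied directly to the core of compound 2. Among the compounds shown here, there is only a single pair on each core, and the two pairs differ both in the core and in the place of the entering methoxy, which in compound 4 is ortho to a methoxy group and meta to a methoxy group. The data cannot tell these two differences apart, and they do not show how general the reversal is.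

As far as these compounds go, whether an ethoxy group or a hydroxyl group at the same place would follow the methoxy steps on either core remains open. Also open, from the compounds shown here alone, is whether the same steps would appear at other concentrations: each value gives only a stronger or weaker effect at the one concentration tested.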